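Swapping a Methyl for a Cyclohexyl on a Receptor Agonist

This account rests on a few compounds, and the source may have more. Where it says the series, first, only, none or still open, it means among the compounds named here.

Compound 1 `Cc1ccc(-c2nc3sccn3c2/C=N/OCc2ccc(Cl)c(Cl)c2)cc1` is measured in an assay on HepG2 cells for agonist activity at nuclear receptor subfamily 1 group I member 3 (Homo sapiens), read by a luciferase reporter, with a stated time of 23 h (a higher number here means that more compound is needed for the effect, a lower number that less compound is needed), and gives 490 nM. Compound 2 `Fc1c(F)c(F)c(CO/N=C/c2c(-c3ccc4ccccc4c3)nc3occn23)c(F)c1F` gives 1700 nM in this assay. Of the two numbers, compound 1 has the lowest, and the gap to compound 2 lies beyond the usual scatter of such measurements. Among the measured compounds shown here, no pair of measured compounds differs in a single place, so no measured step guides the next change.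

Compound 3 `Clc1ccc(CO/N=C/c2c(-c3ccc(C4CCCCC4)cc3)nc3sccn23)cc1Cl` differs from compound 1 by cyclohexyl in place of methyl on an aromatic carbon. For the measured compounds named here, with no comparable measured step available, only a modest change is expected from compound 1 to compound 3, in either direction, and it may well stay within the scatter. The estimate for compound 3 in this assay is 700 nM, with a range from 200 nM to 2500 nM, which means an expected step of a 1.4-fold higher number from compound 1 to compound 3 (0.15 log units; within the scatter).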

Compound 3, half-maximal effective concentration: > 100000 nM
Compound 3: only a limit was reported (the forecaster's own chance of this, stated with the estimate: 10%); at least 140-fold (2.15 log units) between middle value and limit.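

The earlier compounds shown here offered no measured step, so nothing showed how much this position matters; now a single change on an aromatic carbon, para to a large group, has a very large effect. Cyclohexyl in place of methyl gives an at least 200-fold higher number from compound 1 to compound 3 (2.30 log units; beyond the scatter), so the position does not accept every carbon-only group, even though neither group has hydrogen-bond donors or acceptors and the rest of the molecule is unchanged. For compound 3 the reading is a limit of the assay and not a number: the limit of > 100000 nM in this assay, at which 1 of the 3 values shown sits.

On these data alone, what stays open is whether this loss belongs to cyclohexyl alone or would also appear with an ethyl, an isopropyl or a methoxy group in the same place. The compounds shown also do not tell whether the same swap would have a similar effect on the core of compound 2.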